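Moving the Chlorine Across the Pendant Phenyl Ring

The compounds below may be only part of what the source reports. "The series", "measured", "known", "first", "only" and "open" are said of these compounds alone.

Among the compounds with values here, compound 2 `Cc1ccc(S(=O)(=O)c2cnc3cc(F)ccc3c2-c2ccc(Cl)cc2)cc1C` gives 7.88 mL/min in an ADME assay on microsomes from liver (Homo sapiens) for metabolic stability, tested at 2.5 uM (on this read-out lower numbers stand for slow clearance and higher numbers for fast clearance), the highest of the two numbers measured so far; compound 1 `O=S(=O)(c1ccc(F)c(F)c1)c1cnc2cc(F)ccc2c1-c1ccc(Cl)cc1` gives 0.01 mL/min. Compound 3 `Cc1ccc(S(=O)(=O)c2cnc3cc(F)ccc3c2-c2cccc(Cl)c2)cc1C` differs from compound 2 in one place: 3-chlorophenyl in place of 4-chlorophenyl on an aromatic carbon. Within the data shown here, the only measured step, a 790-fold higher number from compound 1 to compound 2 (2.90 log units; beyond the scatter), alters a different part of the shared core, so it does not speak to this change. Among the measured compounds shown here, with no step touching this position, the expected step is a 1.1-fold lower number from compound 2 to compound 3 (0.05 log units; within the scatter), none beyond the scatter. Compound 3 is therefore estimated at 7 mL/min, within a range from 2.5 mL/min to 20 mL/min.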

Compound 3, intrinsic clearance in a liver preparation (reported as CLH), per the amount of preparation that the assay uses: 4.01 mL/min
The estimate for compound 3 lay 1.7-fold (0.24 log units) above the measured number, and the stated range covers the measured number.
By their numbers in this assay, from the lowest: compound 1; then compounds 3 and 2 (each within the scatter of the next).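

Moving the chlorine, so that 3-chlorophenyl stands in place of 4-chlorophenyl on this aromatic carbon, gives a 2.0-fold lower number from compound 2 to compound 3 (0.29 log units; within the scatter) in this assay. Clearance in this assay therefore shows no real response to this move on the 3,4-dimethylphenyl compounds, unlike the large step seen earlier at the sulfonyl sulfur. No measurement at hand explains this result.

As far as these compounds go, it remains open whether the same move would also make no real difference alongside the 3,4-difluorophenyl group of compound 1. Also open, from the compounds shown here alone, is how this ring would read with a methoxy group, a nitrile or an amine in place of the chlorine.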